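A few compounds are considered here, and "the series" means these few. Any claim that something is new, unique, unknown or untested is made for them only; others in the source may bear on it.

Compound 1 `C/C(=N\Nc1nc(-c2ccccc2)cs1)c1sc(C)nc1C`, compound 2 `C/C(=N\Nc1nc(-c2ccc(F)cc2)cs1)c1sc(C)nc1C` and compound 3 `C/C(=N\Nc1nc(-c2ccc(Cl)cc2)cs1)c1sc(C)nc1C` share one core and differ only at a single aromatic carbon. In a toxicity assay on HCT-116 cells (Homo sapiens) for cytotoxicity, read by MTT assay (on this read-out higher numbers stand for weaker inhibition of growth and lower numbers for stronger inhibition of growth), compound 1 gives only a limit, > 100 ug/mL, not a number. Compound 2 likewise gives only a limit, > 100 ug/mL. Compound 3 too reaches only a limit, > 100 ug/mL. The steps a step that the two limits leave unreadable from compound 1 to compound 2, a step that the two limits leave unreadable from compound 1 to compound 3 and a step that the two limits leave unreadable from compound 2 to compound 3 are therefore unreadable, since (the limit of > 100 ug/mL in this assay, at which 3 of the 3 values shown sit). Compound 4 `C/C(=N\Nc1nc(-c2ccc(Br)cc2)cs1)c1sc(C)nc1C` differs from compound 3 by bromo in place of chloro on an aromatic carbon. Going by the values given here, no measured step speaks to this change, so the expectation rests on three limits alone, and compound 4 is expected to give 150 ug/mL, with a range from 50 ug/mL to 400 ug/mL. The step this estimate means is expected to be a step that the limit leaves unreadable from compound 3 to compound 4.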

Compound 4, concentration for 50% growth inhibition: > 100 ug/mL
Compound 4 gave a limit, no number; the forecaster's own chance of this, stated with the estimate: 80%; the middle value is on the limit's open side.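

Going by these compounds alone, compound 4 also gives only a limit, so no step among compound 1, compound 2, compound 3 and compound 4 can be read: the limit of > 100 ug/mL in this assay, at which 4 of the 4 values shown sit.

In this assay the compounds shown leave open whether hydrogen, fluoro, chloro or bromo on this aromatic carbon makes any difference to growth inhibition.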